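A few compounds are considered here, and "the series" means these few. Any claim that something is new, unique, unknown or untested is made for them only; others in the source may bear on it.

Two compounds have been measured in an ADME assay on HEp-2 cells (Homo sapiens) for cytotoxicity; on this read-out lower numbers stand for higher toxicity in this test and higher numbers for lower toxicity in this test:

compound 1 `CC(C)CCn1c(Cn2c(=O)n(C(C)C)c3ccccc32)nc2cc(CN)ccc21` with 3920 nM
compound 2 `CC(C)CCn1c(Cn2c(=O)n(CC(=O)OC(C)(C)C)c3ccccc32)nc2cc(C#N)ccc21` with 32200 nM

Compound 1 stands at the lowest of the two numbers, which on this read-out means it is the more toxic of the pair, and its gap to compound 2 lies beyond the usual scatter of repeated measurements. The untested compound 3 `CC(C)CCn1c(Cn2c(=O)n(C(C)C)c3ccccc32)nc2cc(-c3ncon3)ccc21` is built from compound 1 by a single change: 1,2,4-oxadiazol-3-yl in place of aminomethyl on an aromatic carbon. Among the compounds with values here, no step between two measured compounds that differ in only one place is available, so the size of such a step cannot be read from the data. Compound 2 gives a higher number than compound 1, but it differs from compound 1 in more than one place and therefore offers no direct guide to this change. In this assay a modest move toward a higher number, meaning lower toxicity, is expected for compound 3, of a size that may only just pass the scatter. Compound 3 is expected to give about 8000 nM, within 2500 nM to 30000 nM. That corresponds to an expected step of a 2.0-fold higher number from compound 1 to compound 3 (0.31 log units; beyond the scatter).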

Compound 3, half-maximal cytotoxic concentration: 223000 nM
Compound 3: the middle estimate sits 28-fold (1.45 log units) below what was measured, outside the stated range (above it).
By their numbers in this assay, from the lowest: compound 1; then compound 2; then compound 3.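

In this assay, compounds 1 and 3 form the first pair shown that differs in only one place, and they show that this position on the shared core can strongly change the read-out. Placing 1,2,4-oxadiazol-3-yl on this aromatic carbon in place of aminomethyl gives a 57-fold higher number from compound 1 to compound 3 (1.76 log units; beyond the scatter) and so a large move toward lower toxicity in this test, with the rest of the molecule unchanged. No available measurement bears on what lies behind the size of this step.

This single swap removes aminomethyl, with its hydrogen-bond donor, and also brings in a five-membered aromatic ring, so the compounds shown leave open whether the loss of the first or the arrival of the second matters more. Other groups on the same aromatic carbon of compound 1, such as a methyl group, a carboxylic acid or a longer aminoethyl chain, would help separate these two parts of the change.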